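A few compounds are considered here, and "the series" means these few. Any claim that something is new, unique, unknown or untested is made for them only; others in the source may bear on it.

Compound 1, `COc1ccc(/C=C/C(=O)/C=C/c2ccc(OCc3cn(CCCCCOc4cc(=O)oc5ccccc45)nn3)c(OC)c2)cc1OC`, gives 47%.
Compound 2, `COc1ccc(/C=C/C(=O)/C=C/c2ccc(OCc3cn(CCCCCOc4cc(=O)oc5ccccc45)nn3)c(OC)c2)cc1`, gives 39%.
Compound 3, `COc1ccc(/C=C/C(=O)/C=C/c2ccc(OCc3cn(CCCOc4cc(=O)oc5ccccc45)nn3)c(OC)c2)cc1`, gives 56%.

These three were tested in a functional assay on THP-1 cells (Homo sapiens) for inhibition, read by sulforhodamine B assay, with a stated time of 48 h, tested at 50 uM; a higher number here means more inhibition of growth at the concentration tested, a lower number less inhibition of growth. From compound 1 to compound 2 the change hydrogen in place of methoxy on an aromatic carbon made a step of a number 8 percentage points lower from compound 1 to compound 2 (within the scatter). Compound 3 and compound 1 differ in a larger part of the molecule, and the difference between the two cores is not broken down here. Compound 4, `COc1cc(/C=C/C(=O)/C=C/c2ccccc2)ccc1OCc1cn(CCCOc2cc(=O)oc3ccccc23)nn1`, carries the same kind of change as that between compound 1 and compound 2, namely (hydrogen in place of methoxy on an aromatic carbon); the surroundings differ, the earlier site being ortho to a methoxy group and meta to a large group, the new one para to a large group. Compound 4 is therefore expected to sit close to compound 3, with a step of a number 8 percentage points lower from compound 3 to compound 4 (within the scatter), because the step of a number 8 percentage points lower from compound 1 to compound 2 (within the scatter) was within the scatter. The estimate for compound 4 is 48%, between 35% and 60%.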

Compound 4, percent growth inhibition at one concentration: 48%
For compound 4 middle estimate and measured number coincide at the digits printed; the range from low to high includes it.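

In this assay, hydrogen in place of methoxy at the new site, para to a large group, gave a step of a number 8 percentage points lower from compound 3 to compound 4 (within the scatter). Set beside the earlier step, the change carried from one core to the other with no difference that can be read: the same change on two cores in this assay, a number 8 percentage points lower (within the scatter) from compound 1 to compound 2 and a number 8 percentage points lower (within the scatter) from compound 3 to compound 4, 0 percentage points apart, within the scatter of two such steps. Going by these compounds alone, both steps lie within the scatter, so this shows only that the change left no readable mark on either core at this single concentration; it does not show that methoxy is without influence in general, and it rests on just two pairs with different sites.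

The compounds shown leave open whether an amine, a hydroxyl or a fluorine at these sites would read the same way. They also leave open how the change would behave on a core carrying a longer chain.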